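The source may report more compounds than this note shows. Statements on the series, on what has been measured and on what is new or still open speak of the compounds shown alone.

Compound 1 `O=c1oc2ccccc2c(N2CCN(c3ccccc3F)CC2)c1CO`: > 50000 nM, a limit
Compound 2 `COc1ccccc1N1CCN(c2c(CO)c(=O)oc3ccccc23)CC1`: > 50000 nM, a limit

Both entries come from a toxicity assay on HEK-293T cells (Homo sapiens) for inhibition, read by MTT assay, with a stated time of 24 h; on this read-out lower numbers stand for higher toxicity in this test and higher numbers for lower toxicity in this test. Neither is an exact number, and the limit of > 50000 nM in this assay, at which 2 of the 2 values shown sit, sums up the position: compound 2 stands at the assay limit, with no exact value to place it against compound 1.

Compound 3 `CCN1CCN(c2c(CO)c(=O)oc3ccccc23)CC1` has not yet been measured. It carries one change from compound 2, ethyl in place of 2-methoxyphenyl on an amine nitrogen in a ring.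

Among the compounds with values here, only one measured step bears on this, a step that the two limits leave unreadable from compound 1 to compound 2. It swaps methoxy for fluoro on an aromatic carbon, leaves the aromatic ring in place, and gives no size to carry over. The new change removes that ring, which neither measured compound tests, so the forecast is uncertain.

In this assay, no step beyond the usual scatter is expected in either direction. This expectation rests on compound 2, whose limit is > 50000 nM. The expected step is a step that the limit leaves unreadable from compound 2 to compound 3. Compound 3 is estimated at 60000 nM, with an expected range from 25000 nM to 150000 nM.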

Compound 3, half-maximal cytotoxic concentration: > 50000 nM
Compound 3: only a limit was reported; the forecaster's own chance of this, stated with the estimate: 80%; the middle value lies beyond the limit too.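

No step can be read among compound 1, compound 2 and compound 3, since each result in this assay is a limit and not an exact number: the limit of > 50000 nM in this assay, at which 3 of the 3 values shown sit.

The compounds shown leave open where the true value of each lies, and whether methoxy, fluoro or ethyl in these places changes toxicity in this test at all.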